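This account rests on a few compounds, and the source may have more. Where it says the series, first, only, none or still open, it means among the compounds named here.

Compounds measured in an assay on HeLa cells for inhibition of sphingosine-1-phosphate transporter SPNS2 (Mus musculus), read by LC-MS, tested at 2 uM (a higher number here means more inhibition at the concentration tested (going by the name of the read-out), a lower number less inhibition), so far:

Compound 1 `CCCCCCCCCCc1ccc(-c2noc(CCCNC)n2)cc1`: 45%
Compound 2 `CCCCCCCCCCc1ccc(-c2noc([C@H]3CCC[C@@H](N)C3)n2)cc1`: 29%
Compound 3 `CCCCCCCCCCc1ccc(-c2noc([C@@H](N)CCN)n2)cc1`: 14%

Compound 3 gives the lowest inhibition of the three; compound 2 stands nearest, and the gap is a number 15 percentage points lower from compound 2 to compound 3 (beyond the scatter), while compound 1 stands furthest, the gap being a number 31 percentage points lower from compound 1 to compound 3 (beyond the scatter). Both steps into compound 3 lie beyond the scatter, so the 1,3-diaminopropyl group gives, on these numbers, the lowest inhibition in this assay of the three substituents tried on this aromatic carbon of the shared core.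

Compound 4 `CCCCCCCCCCc1ccc(-c2noc(CC(O)CN3CCCC3)n2)cc1` has not yet been measured. It differs from compound 3 in one place: 2-hydroxy-3-(pyrrolidin-1-yl)propyl in place of 1,3-diaminopropyl on an aromatic carbon. The change sits at the same aromatic carbon where compounds 1, 2 and 3 differ, so the steps 1>3 and 2>3 bear on it, both showing that leaving the 1,3-diaminopropyl group for another substituent corresponds to a higher reading. The entering 2-hydroxy-3-(pyrrolidin-1-yl)propyl group matches none of the groups already measured, so the size of the step is uncertain.

An increase beyond the scatter is expected, roughly a number 19 percentage points higher from compound 3 to compound 4 (beyond the scatter). Compound 4 is estimated at 33%, within a range of 12% to 54%.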

Compound 4, a percentage reported as inhibition, at one concentration (the size of the read-out at that concentration, not a potency): 21%
Estimate against measurement, compound 4: 12 percentage points above; measured number inside the range.
By their numbers in this assay, from the lowest: compounds 3, 4 and 2 (each within the scatter of the next, the first and the last beyond it); then compound 1.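

In this assay the 2-hydroxy-3-(pyrrolidin-1-yl)propyl group, placed on the aromatic carbon next to the ring nitrogen and the ring oxygen, gives a number 7 percentage points higher from compound 3 to compound 4 (within the scatter) against 1,3-diaminopropyl and a number 8 percentage points lower from compound 2 to compound 4 (within the scatter) against 3-aminocyclohexyl, so compound 4 cannot be told apart from either of these two, although they stand beyond the scatter of each other. Only the step of a number 24 percentage points lower from compound 1 to compound 4 (beyond the scatter) separates compound 4 from another compound, which leaves 3-(methylamino)propyl as the one substituent shown that reads clearly apart from the new group. Nothing measured on these compounds accounts for these readings.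

The new group brings a hydroxyl and a pyrrolidine ring in one change, so a plain 3-(pyrrolidin-1-yl)propyl group and a 2-hydroxy-3-(methylamino)propyl group would be needed to read each part on its own against compound 1. The compounds shown also all keep the decyl chain of the shared core, so whether these substituent steps hold with a shorter alkyl chain there remains open.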